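Two Measured Anilides and a Third Awaiting Its Number

The compounds below may be only part of what the source reports. "The series", "measured", "known", "first", "only" and "open" are said of these compounds alone.

Compound 1 `Cn1c(-c2ccc(NC(=O)CCl)cc2)nc(-c2ccccc2)c1-c1ccccc1`: 70%
Compound 2 `Cc1ccc2oc(SCC(=O)Nc3ccc(-c4nc(-c5ccccc5)c(-c5ccccc5)n4C)cc3)nc2c1`: 65.1%

In a functional assay on MCF7 cells (Homo sapiens) for cytotoxicity, read by MTT assay, with a stated time of 24 h, tested at 80 ug/mL (a higher number here means a stronger effect of the compound at the concentration tested, a lower number a weaker effect), compound 1 gives 70%. Compound 2 gives 65.1% in this assay. Among the compounds with values here, the only step measured so far, a number 4.9 percentage points lower from compound 1 to compound 2 (within the scatter), replaced the chloro on a saturated chain carbon bound to a carbonyl carbon by a (5-methyl-1,3-benzoxazol-2-yl)sulfanyl group, and compound 2 therefore stands level with compound 1, the two numbers within the scatter of each other.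

Compound 3 `Cc1nnc(SCC(=O)Nc2ccc(-c3nc(-c4ccccc4)c(-c4ccccc4)n3C)cc2)s1` has not yet been measured. Its difference from compound 2 is 5-methyl-1,3,4-thiadiazol-2-yl in place of 5-methyl-1,3-benzoxazol-2-yl on a sulfur. Within the data shown here, no measured step exchanges one sulfanyl-bound ring for another, so the step from compound 1 to compound 2 is the only one that bears on it: it changed the same end of the chain by a much larger amount and moved the number only within the scatter. The expectation for compound 3 is thus a step of a number 0.1 percentage points lower from compound 2 to compound 3 (within the scatter), no direction beyond the scatter. Compound 3 is estimated at 65%, between 50% and 78%.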

Compound 3, a percentage reported as activity, at one concentration (the size of the read-out at that concentration, not a potency): 85.2%
Beside the measured number, compound 3's estimate is 20.2 percentage points below it; measured number above the stated range.
By their numbers in this assay, from the lowest: compounds 2 and 1 (each within the scatter of the next); then compound 3.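

In this assay, within the data shown here, exchanging 5-methyl-1,3-benzoxazol-2-yl for 5-methyl-1,3,4-thiadiazol-2-yl on the sulfur gave a number 20.1 percentage points higher from compound 2 to compound 3 (beyond the scatter) and so showed that the read-out responds to the identity of this ring, which the earlier compounds could not show. The sulfanyl group alone does not settle the outcome: where the (5-methyl-1,3-benzoxazol-2-yl)sulfanyl group in place of chloro had left the number within the scatter, the (5-methyl-1,3,4-thiadiazol-2-yl)sulfanyl group made the same exchange with a number 15.2 percentage points higher from compound 1 to compound 3 (beyond the scatter) and placed compound 3 highest of the three. The entering ring has fewer heavy atoms and one ring against two, but nothing measured here tells which difference between the two groups goes with the higher number.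

Going by these compounds, it remains open whether the higher number depends on the methyl group or on the ring's sulfur, which a 5-methyl-1,3,4-oxadiazol-2-yl group or an unsubstituted 1,3,4-thiadiazol-2-yl group on the same sulfur could help to separate. Since the read-out comes from one concentration and gives no potency, the compounds shown also leave open whether compound 3 would keep its place across a range of concentrations.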